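The compounds below may be only part of what the source reports. "The series", "measured", "known", "first", "only" and "open" are said of these compounds alone.

Measured compounds:
Compound 1 `CCOc1c(-c2occ(C)c2C(=O)OC)ccc2c(CC)cccc12`: in a functional assay on ZR-75-1 cells (Homo sapiens) for cytotoxicity, read by MTT assay, with a stated time of 72 h (on this read-out lower numbers stand for an effect already at smaller amounts and higher numbers for an effect only at larger amounts of compound), compound 1 gives 1.2 ug/mL.
Compound 2 `CCOc1c(-c2occ(C)c2CO)ccc2c(CC)cccc12`: in this assay compound 2 gives 1.4 ug/mL.
Compound 3 `CCc1cccc2c(OC)c(-c3occ(C)c3COC)ccc12`: in this assay compound 3 gives 9.7 ug/mL.

Only one pair of these compounds differs in a single place: the step of a 1.2-fold higher number from compound 1 to compound 2 (0.07 log units; within the scatter), which changes nothing that the assay can resolve. Compound 3 stands apart, with the highest of the three numbers, and its gaps to compound 2 and to compound 1 both lie beyond the scatter.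

The next compound, compound 4 `CCOc1c(-c2occ(C)c2COC)ccc2c(CC)cccc12`, is reached from compound 3 by methyl in place of hydrogen on a saturated chain carbon bound to an oxygen on an aromatic ring, so that a methoxy becomes an ethoxy. Among the compounds with values here, no measured step touches this part of the structure; the one measured step concerns the group on the furan and says nothing about the chain on the oxygen. Compounds 1 and 2 do carry the ethoxy that compound 4 will carry, and both give lower numbers than compound 3, but they also differ from compound 3 on the furan, so the two changes cannot be separated.

Compound 4 is therefore expected to give an intermediate number, a step of a 2.4-fold lower number from compound 3 to compound 4 (0.38 log units; beyond the scatter) downward from compound 3, with wide uncertainty: the estimate for compound 4 is 4 ug/mL, between 1.5 ug/mL and 11 ug/mL.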

Compound 4, concentration for half-maximal effect: > 10 ug/mL
Compound 4: a limit, no number (the forecaster's own chance of this, stated with the estimate: 5%); middle value at least 2.5-fold (0.39 log units) from the limit.
By their numbers in this assay, from the lowest: compounds 1 and 2 (each within the scatter of the next); then compound 3. At a limit, above all of these: compound 4.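

In this assay compound 4 gives > 10 ug/mL, which is a limit and not a number: the limit of > 10 ug/mL in this assay, at which 1 of the 4 values shown sits. For the change from methoxy to ethoxy on the saturated chain carbon bound to an oxygen on an aromatic ring, the result is an at least 1.0-fold higher number from compound 3 to compound 4 (0.01 log units; that floor lies within the scatter), so this change does not lower the number here, and how far it may raise it cannot be told. The group on the aromatic carbon, whose exchange gave only a 1.2-fold higher number from compound 1 to compound 2 (0.07 log units; within the scatter), now clearly matters with the ethoxy kept in place: putting methyl in place of hydrogen on the oxygen of the hydroxymethyl gives an at least 7.1-fold higher number from compound 2 to compound 4 (0.85 log units; beyond the scatter), and methoxymethyl in place of methoxycarbonyl gives an at least 8.3-fold higher number from compound 1 to compound 4 (0.92 log units; beyond the scatter).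

The compounds shown leave open how far past its limit compound 4 truly lies, and so how large the change from methoxy to ethoxy really is. They also leave open how an aminomethyl or a carboxylic acid would read on that aromatic carbon, and how a longer chain such as propoxy would read on the oxygen.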